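Adding a dichlorophenylcarbonyl group to compound 1

The source may hold more compounds than are shown below. What is called first, only, known or untested is meant among the compounds shown, and "the series" means these compounds.

Compound 1, `CC(C)(C)OC(=O)CN1C(=O)C(N)CCc2ccccc21`: 100000 nM
Compound 2, `CC(C)(C)OC(=O)CN1C(=O)C(NC(=O)c2ccc(Cl)cc2)CCc2ccccc21`: 130 nM

In an assay for binding affinity to Cholecystokinin receptor (Rattus norvegicus), read by CCK-8 assay (a lower number here means a stronger inhibitor, a higher number a weaker inhibitor), compound 1 gives the highest number of the two measured. Its nearest neighbour is compound 2, reached by a 770-fold lower number from compound 1 to compound 2 (2.89 log units; beyond the scatter), with a (4-chlorophenyl)carbonyl in place of hydrogen on an amine nitrogen. Compound 3, `CC(C)(C)OC(=O)CN1C(=O)C(NC(=O)c2ccc(Cl)c(Cl)c2)CCc2ccccc21`, makes a closely related change: (3,4-dichlorophenyl)carbonyl in place of hydrogen on an amine nitrogen. For the measured compounds named here, only the step from compound 1 to compound 2 bears on this, and it was large, so a fall of similar size in this assay is expected. Compound 3 is estimated at 100 nM, between 20 nM and 600 nM, an expected step of a 1000-fold lower number from compound 1 to compound 3 (3.00 log units; beyond the scatter).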

Compound 3, half-maximal inhibitory concentration: 28 nM
Compound 3: the middle estimate sits 3.6-fold (0.55 log units) above what was measured, within the range that was stated.
By their numbers in this assay, from the lowest: compound 3; then compound 2; then compound 1.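

In this assay, the aromatic ring of the new amide still responds to change: a second chloro gives a 4.6-fold lower number from compound 2 to compound 3 (0.67 log units; beyond the scatter) and so adds a modest gain to what the (4-chlorophenyl)carbonyl group already brought. The complete (3,4-dichlorophenyl)carbonyl group gives a 3600-fold lower number from compound 1 to compound 3 (3.55 log units; beyond the scatter) and most of that gain already appears with the single chloro. Nothing available explains why the second chloro lowers the number. From the compounds shown here alone, whether this gain needs a chloro at all remains open, since a methyl or methoxy group in its place could behave differently.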